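The source may report more compounds than this note shows. Statements on the series, on what has been measured and on what is new or still open speak of the compounds shown alone.

In a functional assay on OCI-AML2 cells (Homo sapiens) for antiproliferative activity, read by WST assay, with a stated time of 3 days (on this read-out higher numbers stand for weaker inhibition and lower numbers for stronger inhibition), compound 1 (`CNc1cc(=O)[nH]c(=O)n1[C@@H]1O[C@H](CO)[C@@H](O)[C@H]1O`) gives > 50000 nM, which is a limit of the assay. Compound 2 (`O=Cc1cc(=O)[nH]c(=O)n1[C@@H]1O[C@H](CO)[C@@H](O)[C@H]1O`) gives > 50000 nM, which is also a limit. For the measured compounds named here, the whole series so far is summed up by the limit of > 50000 nM in this assay, at which 2 of the 2 values shown sit, so compound 2 stands without a number. Compound 3 (`O=Cc1c(F)c(=O)[nH]c(=O)n1[C@@H]1O[C@H](CO)[C@@H](O)[C@H]1O`) differs from compound 2 by fluoro in place of hydrogen on an aromatic carbon, ortho to a formyl group. Going by the values given here, the only measured step is a step that the two limits leave unreadable from compound 1 to compound 2, and it offers no size to carry over. Among the compounds with values here, no step with fluoro entering has been measured. Compound 2 at > 50000 nM, a limit, is the sole anchor, so the expectation stays near that limit, with some room for stronger inhibition in this assay. The estimated step is an at least 1.6-fold lower number from compound 2 to compound 3 (0.22 log units; that floor lies within the scatter). Compound 3 is expected at 30000 nM, with an estimated range from 4000 nM to 80000 nM.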

Compound 3, half-maximal inhibitory concentration: 700 nM
The estimate for compound 3 lay 43-fold (1.63 log units) above the measured number; the measured number lies below the stated range.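

At this position, ortho to a formyl group, fluoro in place of hydrogen gives an at least 71-fold lower number from compound 2 to compound 3 (1.85 log units; beyond the scatter) in this assay. For the compounds shown here, this is the first readable change, and it shows that the shared core can reach a measurable antiproliferative effect in these cells through a single added fluorine. As the step starts from a limit, its printed size is a floor, and compound 3 alone carries a number, the other compounds resting at the limit of the assay: the limit of > 50000 nM in this assay, at which 2 of the 3 values shown sit.

The compounds shown leave open whether chloro or methyl on this carbon would give a comparable drop, and whether fluoro would do the same with methylamino in place of formyl. As far as these compounds go, the step between compound 1 and compound 2 cannot be read, so the share of the formyl group in this result also stays open.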